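A few compounds are considered here, and "the series" means these few. Any claim that something is new, unique, unknown or untested is made for them only; others in the source may bear on it.

Measured so far:
Compound 1, `CCCCOCCn1c(N2CCN(C)CC2)nc2ccccc21`: 38 nM
Compound 2, `CCOCCn1c(N2CCN(CC)CC2)nc2ccccc21`: 18 nM
Compound 3, `CCCCOCCn1c(N2CCCN(C)CC2)nc2ccccc21`: 10 nM

Of the three compounds measured in a functional assay on ileum for inhibition of histamine H1 receptor (Cavia porcellus) (a lower number here means a stronger inhibitor, a higher number a weaker inhibitor), compound 1 gives the highest number, with compound 2 the nearest and compound 3 the furthest away. Among the measured compounds shown here, the one single-point step among them is a 3.8-fold lower number from compound 1 to compound 3 (0.58 log units; beyond the scatter), a change at the saturated ring on the shared core. Compound 2 differs from compound 1 in two places at once, so its value cannot be tied to any one change.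

Compound 4, `CN1CCN(c2nc3ccccc3n2CCOc2ccccc2)CC1`, is not yet measured. It differs from compound 1 as follows: phenyl in place of butyl on an oxygen on a saturated carbon. For the measured compounds named here, none of the measured steps touches this oxygen-linked group; the one step known concerns a different part of the molecule, and the pair of compounds 1 and 2 changes the ether chain only together with a second change. Going by the values given here, there is therefore no measured step that bears directly on the butoxy to phenoxy exchange, and the direction of its effect cannot be read from the data.

He expects compound 4 to stay close to compound 1 in this assay, with a step of a 1.3-fold lower number from compound 1 to compound 4 (0.10 log units; within the scatter), which is within or near the scatter. His estimate for compound 4 is 30 nM, with a range from 8 nM to 120 nM.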

Compound 4, half-maximal inhibitory concentration: 6.9 nM
For compound 4 the middle estimate is 4.3-fold (0.64 log units) above the measured one, outside the stated range (below it).
By their numbers in this assay, from the lowest: compounds 4, 3 and 2 (each within the scatter of the next, the first and the last beyond it); then compound 1.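

Replacing butyl with phenyl on the oxygen on a saturated carbon gives a 5.5-fold lower number from compound 1 to compound 4 (0.74 log units; beyond the scatter) in this assay, which shows that this position, untouched by the earlier single-point step, responds on its own to a change of group. In this pair, a group with one six-membered aromatic ring of carbon only gives a stronger inhibitor than the open butyl chain. Nothing available explains why this exchange lowers the number.

The compounds shown leave open whether a cyclohexyl or a benzyl on the same oxygen would give a similar result, and so whether the ring itself or its aromatic character goes with the change. They also leave open whether phenoxy and 4-methyl-1,4-diazepan-1-yl would add together on the shared core.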